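The compounds below may be only part of what the source reports. "The series", "measured", "known", "first", "only" and "open" are said of these compounds alone.

Compound 1, `COc1cc(-n2cnc3ccc(-c4ccccc4Cl)cc32)cc(OC)c1OC`: > 10000 nM
Compound 2, `COc1cc(-n2cnc3ccc(-c4ccc(O)cc4)cc32)cc(OC)c1OC`: 5090 nM

Both values come from a functional assay on A549 cells (Homo sapiens) for antiproliferative activity, read by MTT assay, with a stated time of 72 h; on this read-out higher numbers stand for weaker inhibition and lower numbers for stronger inhibition. For compound 1 the result is a limit of the assay rather than a number. Within the data shown here, compound 2 gives the only number in the set, 5090 nM, so it stands alone among the measured compounds. Among the measured compounds shown here, the single measured step, an at least 1.9-fold lower number from compound 1 to compound 2 (0.29 log units; that floor lies within the scatter), brought the series from the limit to that number; the floor of that step lies within the scatter, so its true size is not fixed (the limit of > 10000 nM in this assay, at which 1 of the 2 values shown sits).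

Compound 3, `COc1cc(-n2cnc3ccc(-c4ccc(C)cc4F)cc32)cc(OC)c1OC`, is not yet measured. It differs from compound 2 by 2-fluoro-4-methylphenyl in place of 4-hydroxyphenyl on an aromatic carbon. The entering group, like the 2-chlorophenyl of compound 1, carries no hydrogen-bond donor or acceptor, whereas the leaving 4-hydroxyphenyl carries one of each. For the measured compounds named here, the only guide is the step from compound 1 to compound 2, which suggests that removing the hydroxyl points back toward the limit. Compound 3 is therefore expected to give a somewhat higher number than compound 2, a 1.8-fold higher number from compound 2 to compound 3 (0.25 log units; within the scatter), with a real chance that only a limit is reported. The estimate for compound 3 is 9000 nM, between 3500 nM and 25000 nM.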

Compound 3, half-maximal inhibitory concentration: > 10000 nM
Compound 3 was reported as a limit; the forecaster's own chance of this, stated with the estimate: 45%; middle value at least 1.1-fold (0.04 log units) away from the limit.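

Replacing the 4-hydroxyphenyl with 2-fluoro-4-methylphenyl gives an at least 1.9-fold higher number from compound 2 to compound 3 (0.29 log units; that floor lies within the scatter) in this assay, so the true size of this second change at the aromatic carbon also stays unfixed. The step between compound 1 and compound 3 cannot be read, since both results are limits of the assay and not numbers. The 4-hydroxyphenyl of compound 2 is now the only group at this place to give a number, while two different groups with no hydrogen-bond donor, the 2-chlorophenyl of compound 1 and the 2-fluoro-4-methylphenyl of compound 3, both end at the same limit: the limit of > 10000 nM in this assay, at which 2 of the 3 values shown sit.

The compounds shown do not separate the hydroxyl from the rest of the change, as compound 3 differs from compound 2 by a fluorine and a methyl as well as by the loss of the hydroxyl. Also open, on these data alone, is whether the number of compound 2 depends on the hydroxyl itself, or whether a 4-aminophenyl, a 4-methoxyphenyl or a phenyl carrying a carboxylic acid at the same place would also give a number.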